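Methyl Added to the Aryl Ring of Compound 2

The source may hold more compounds than are shown below. What is called first, only, known or untested is meant among the compounds shown, and "the series" means these compounds.

Compound 2 `CCOC(=O)c1c(-c2c(Cl)c3cc(C)ccc3oc2=O)nn(-c2ccccc2)c1C(=O)OCC` gives 108000 nM in a functional assay on A549 cells (Homo sapiens) for cytotoxicity, read by MTT assay, with a stated time of 48 h (on this read-out lower numbers stand for stronger inhibition and higher numbers for weaker inhibition), the highest of the two numbers measured, while compound 1 `CCOC(=O)c1c(-c2c(Cl)c3ccccc3oc2=O)nn(-c2cccc(C)c2)c1C(=O)OCC` gives 36000 nM, a difference beyond the usual scatter. Compound 3 `CCOC(=O)c1c(-c2c(Cl)c3cc(C)ccc3oc2=O)nn(-c2cccc(C)c2)c1C(=O)OCC` differs from compound 2 by methyl in place of hydrogen on an aromatic carbon, a change that reads as phenyl to 3-methylphenyl. Within the data shown here, no directly comparable step has been measured. Since compound 1 carries the same methylphenyl and gives 36000 nM, a modest move toward lower numbers is expected. Compound 3 is estimated at 60000 nM, between 20000 nM and 160000 nM, the expected step being a 1.8-fold lower number from compound 2 to compound 3 (0.26 log units; within the scatter).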

Compound 3, half-maximal inhibitory concentration: 115000 nM
Compound 3: middle estimate off by 1.9-fold (0.28 log units), on the low side; measured number inside the range.
By their numbers in this assay, from the lowest: compound 1; then compounds 2 and 3 (each within the scatter of the next).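

In this assay the change from phenyl to 3-methylphenyl stays within the scatter, at a 1.1-fold higher number from compound 2 to compound 3 (0.03 log units; within the scatter), so this position shows no measurable response to methyl when the other methyl is present. The same kind of change at a different aromatic carbon, made on compound 1, lies beyond the scatter, at a 3.2-fold higher number from compound 1 to compound 3 (0.50 log units; beyond the scatter), so the two methyl changes do not read alike. Nothing measured here accounts for this difference. The compounds shown leave open whether phenyl to 3-methylphenyl reads the same without that other methyl. They also leave open whether an amine or a carboxylic acid in place of this methyl would move the number.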